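Swapping the methoxyphenyl of compound 1 for a thiophene

A few compounds are considered here, and "the series" means these few. Any claim that something is new, unique, unknown or untested is made for them only; others in the source may bear on it.

Measured so far:
compound 1 `COc1ccc(C2C(C#N)=C(N)N(c3ccc(S(N)(=O)=O)cc3)C3=C2CCCC3)cc1` gives 100%
compound 2 `COc1ccc(C2C(C#N)=C(N)N(c3ccc(S(N)(=O)=O)cc3)C3=C2CCCC3)c2ccccc12` gives 10%

Compound 1, with the structure `COc1ccc(C2C(C#N)=C(N)N(c3ccc(S(N)(=O)=O)cc3)C3=C2CCCC3)cc1`, stands highest of the two numbers in a functional assay on Ehrlich cells (Mus musculus) for cytotoxicity, read by trypan blue exclusion, with a stated time of 2 h, tested at 50 ug/mL; a lower number here means a weaker effect, a higher number a stronger effect of the compound at the concentration tested. In this assay compound 1 gives 100%. For the measured compounds named here, the only neighbour is compound 2, with the structure `COc1ccc(C2C(C#N)=C(N)N(c3ccc(S(N)(=O)=O)cc3)C3=C2CCCC3)c2ccccc12`, which in this assay gives 10%; the gap between these two values lies well beyond the scatter, so compound 1 is the stronger of the two.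

Compound 3, with the structure `N#CC1=C(N)N(c2ccc(S(N)(=O)=O)cc2)C2=C(CCCC2)C1c1cccs1`, has not been measured. Compared with compound 1, the change is thiophen-2-yl in place of 4-methoxyphenyl on a saturated ring carbon. Going by the values given here, no other pair here isolates this change, so nothing directly tells how large a step it brings. Since compound 1 already sits at the top of the scale, a move beyond the scatter can only go downward, and a change of the aryl group is expected to cost some activity.

The expected step is a number 30 percentage points lower from compound 1 to compound 3 (beyond the scatter). Compound 3 is therefore estimated at 70%, within a range from 25% to 100%.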

Compound 3, a percentage reported as activity, at one concentration (the size of the read-out at that concentration, not a potency): 10%
Estimate against measurement, compound 3: 60 percentage points above; measured number below the stated range.
By their numbers in this assay, from the lowest: compounds 2 and 3 (each within the scatter of the next); then compound 1.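

In this assay, putting thiophen-2-yl in place of 4-methoxyphenyl on the saturated ring carbon brings a large change: a number 90 percentage points lower from compound 1 to compound 3 (beyond the scatter). So the high value of compound 1 does not simply come with having any aromatic ring at this carbon, and it depends strongly on which ring sits there. Compound 2, with a larger aromatic group at this carbon, gives 10% and compound 3, with a smaller one, gives 10%, so in this small set, departures from 4-methoxyphenyl in either direction of size go with a low reading, though no measurement shown explains the loss.

The compounds shown leave open whether the loss follows the removal of the methoxy group or the change from a six-membered aromatic ring to a five-membered one with sulfur, and a plain phenyl group or a 4-methylphenyl group at this carbon would help to separate the two. They also leave open how these compounds compare at lower concentrations, as each reading comes from one concentration and is not a potency.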